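Cytotoxicity in the urea series: the trifluoromethyl position

This account rests on a few compounds, and the source may have more. Where it says the series, first, only, none or still open, it means among the compounds named here.

Measured compounds in an ADME assay on WI-38 cells (Homo sapiens) for cytotoxicity, read by MTT assay, with a stated time of 72 h; a lower number here means a stronger inhibitor, a higher number a weaker inhibitor:
compound 1, `CN(C)CCn1cnnc1-c1cc(Oc2ccc(NC(=O)Nc3ccccc3C(F)(F)F)cc2F)ccn1`: > 50000 nM
compound 2, `CCN(CC)CCn1cnnc1-c1cc(Oc2ccc(NC(=O)Nc3ccccc3C(F)(F)F)cc2F)ccn1`: 23500 nM
compound 3, `CN(C)CCCn1cnnc1-c1cc(Oc2ccc(NC(=O)Nc3cccc(C(F)(F)F)c3)cc2F)ccn1`: 11600 nM

The value for compound 1 is a limit of this assay, not a number, as is the limit of > 50000 nM in this assay, at which 1 of the 3 values shown sits. Compound 3 stands lowest of the two numbers shown; the nearest is compound 2, which sits higher, beyond the scatter. Among the measured compounds shown here, the one measured step, an at least 2.1-fold lower number from compound 1 to compound 2 (0.32 log units; beyond the scatter), changes the amine on the chain and says nothing about the trifluoromethylphenyl group on the urea.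

Compound 4, `CN(C)CCCn1cnnc1-c1cc(Oc2ccc(NC(=O)Nc3ccccc3C(F)(F)F)cc2F)ccn1`, is not yet measured. Its difference from compound 3 is 2-(trifluoromethyl)phenyl in place of 3-(trifluoromethyl)phenyl on an amide-type nitrogen. For the measured compounds named here, no measured step covers this change. Going by the values given here, what can be drawn on is only that compound 1 and compound 2, which both carry 2-(trifluoromethyl)phenyl, give the higher values in this assay, while compound 3, with 3-(trifluoromethyl)phenyl, gives the lowest number; these pairs also differ in chain and amine, so the comparison is loose. A modest rise is therefore expected, a 1.7-fold higher number from compound 3 to compound 4 (0.24 log units; within the scatter), though a result within the scatter would not be surprising. Compound 4 is estimated at 20000 nM, between 8000 nM and 50000 nM.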

Compound 4, half-maximal inhibitory concentration: 28600 nM
Beside the measured number, compound 4's estimate is 1.4-fold (0.16 log units) below it; measured number inside the range.
By their numbers in this assay, from the lowest: compound 3; then compounds 2 and 4 (each within the scatter of the next). At a limit, above all of these: compound 1.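

In this assay, among the compounds shown here, the trifluoromethyl position now has a direct reading: with all else held fixed, 2-(trifluoromethyl)phenyl in place of 3-(trifluoromethyl)phenyl on an amide-type nitrogen gives a 2.5-fold higher number from compound 3 to compound 4 (0.39 log units; beyond the scatter), a modest shift toward weaker cytotoxicity that the earlier compounds could only hint at across differing chains and amines. Among the compounds carrying 2-(trifluoromethyl)phenyl, (dimethylamino)methyl in place of diethylamino on a saturated chain carbon, two bonds along the chain from an aromatic nitrogen, gives a 1.2-fold higher number from compound 2 to compound 4 (0.09 log units; within the scatter), so these two side chains are not separated in this assay. At the same place, (dimethylamino)methyl in place of dimethylamino gives an at least 1.7-fold lower number from compound 1 to compound 4 (0.24 log units; that floor lies within the scatter), and of these three steps only the change of trifluoromethyl position lies beyond the scatter. The value of compound 1 is a limit of the assay and not a number: the limit of > 50000 nM in this assay, at which 1 of the 4 values shown sits.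

As far as these compounds go, the effect of the trifluoromethyl position rests on this single matched pair, so whether it holds with a diethylamino group on the chain remains open. Also open, from the compounds shown here alone, is where an unsubstituted phenyl on the amide-type nitrogen, or a morpholine in place of the dimethylamino group, would fall in this assay.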